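Cassette oral bioavailability in a bicyclic amide series

The compounds below may be only part of what the source reports. "The series", "measured", "known", "first", "only" and "open" are said of these compounds alone.

Compound 1 `Cc1ccc(C(=O)Nc2cn3ncnc3c(CN3CCN(C(=O)C4CCCC4)[C@@H](C)C3)c2C)cn1` and compound 2 `Cc1ccc(C(=O)Nc2cc(F)cc(CN3CCN(C(=O)C4CCCC4)[C@@H](C)C3)c2C)cn1` have been measured in an ADME assay on the whole organism (Mus musculus) for pharmacokinetics, using cassette dosing; on this read-out lower numbers stand for lower oral bioavailability and higher numbers for higher oral bioavailability. Compound 1 gives 47%, and compound 2 gives 48%; compound 1 holds the lower of the two numbers, but the gap to compound 2 lies within the scatter, so the two read alike. Compound 3 `Cc1ccc(C(=O)Nc2cn3ncnc3c(CN3CCN(C(=O)CC(C(F)(F)F)C(F)(F)F)[C@@H](C)C3)c2C)cn1` is not yet measured. It differs from compound 1 in one place: 3,3,3-trifluoro-2-(trifluoromethyl)propyl in place of cyclopentyl on a carbonyl carbon. Among the measured compounds shown here, no step between measured compounds covers a change of this kind, so the direction can rest only on compound 1 at 47%. A small step downward beyond the scatter is expected, a number 12 percentage points lower from compound 1 to compound 3 (beyond the scatter). Compound 3 is estimated at 35%, between 15% and 55%.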

Compound 3, oral bioavailability: 110%
The estimate for compound 3 lay 75 percentage points below the measured number; measured number above the stated range.
By their numbers in this assay, from the lowest: compounds 1 and 2 (each within the scatter of the next); then compound 3.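

On a carbonyl carbon, 3,3,3-trifluoro-2-(trifluoromethyl)propyl in place of cyclopentyl gives a number 63 percentage points higher from compound 1 to compound 3 (beyond the scatter) in this assay. Among the compounds shown here, compound 1 and compound 2 both carry cyclopentyl here, so this is the first sign that this position can move the read-out, and by a large step. Nothing at hand bears on the reason for the step.

Open, as far as these compounds go, is whether the step depends on the fluorine: the isobutyl group, or a propyl chain with a single trifluoromethyl, would test this. Also open, from the compounds shown here alone, is whether the same change holds on the core of compound 2.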